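The compounds below may be only part of what the source reports. "The series", "measured", "known", "first", "only" and "open" are said of these compounds alone.

Working notes on the series

Of the compounds shown here, three with a shared core have so far been measured in a functional assay on PC-12 cells (Rattus norvegicus) for cytotoxicity, read by MTT assay, with stated times of 2 h and 24 h, tested at 10 uM; a higher number here means a stronger effect of the compound at the concentration tested, a lower number a weaker effect. Compound 1 `Cc1ccc(-n2nc(-c3ccc(C(F)(F)F)cc3O)nc2-c2ccccc2O)cc1` gives 102%. Compound 2 `Oc1cc(C(F)(F)F)ccc1-c1nc(-c2ccccc2O)n(-c2ccc(Br)cc2)n1` gives 100%. Compound 3 `COc1ccccc1-n1nc(-c2ccc(C(F)(F)F)cc2O)nc1-c1ccccc1O` gives 96.2%. All three numbers sit at about the same level; compound 2 is the second highest of the three, its nearest neighbour being compound 1 and its furthest compound 3, with both gaps inside the scatter, as seen in a number 2 percentage points lower from compound 1 to compound 2 (within the scatter) and in a number 3.8 percentage points lower from compound 2 to compound 3 (within the scatter).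

The next member is compound 4 `Oc1cc(C(F)(F)F)ccc1-c1nc(-c2ccccc2O)n(-c2cccc(C(F)(F)F)c2)n1`. Relative to compound 2 the change is 3-(trifluoromethyl)phenyl in place of 4-bromophenyl on an aromatic nitrogen.

Two of the measured steps also exchange the aryl group on the aromatic nitrogen and therefore bear on this one: a number 5.8 percentage points lower from compound 1 to compound 3 (within the scatter) and a number 3.8 percentage points lower from compound 2 to compound 3 (within the scatter). Neither moved the read-out beyond the scatter, and the swap of methyl for bromo in a number 2 percentage points lower from compound 1 to compound 2 (within the scatter) did not either. On that basis the step to compound 4 is expected to be flat, a number 1 percentage points lower from compound 2 to compound 4 (within the scatter), with no movement beyond the scatter.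

For compound 4 the estimate in this assay is 99%, within a range from 89% to 108%.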

Compound 4, a percentage reported as activity, at one concentration (the size of the read-out at that concentration, not a potency): 99.9%
Compound 4: middle estimate off by 0.9 percentage points, on the low side; the measured number falls inside the stated range.
By their numbers in this assay, from the lowest: compounds 3, 4, 2 and 1 (each within the scatter of the next).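

In this assay, the exchange of 4-bromophenyl for 3-(trifluoromethyl)phenyl on the aromatic nitrogen gives a number 0.1 percentage points lower from compound 2 to compound 4 (within the scatter) and so adds a new kind of aryl group at this position, one with 10 heavy atoms in place of 7 and with 3 fluorine, without any movement beyond the scatter. The comparisons with the other two aryl groups agree, with a number 3.7 percentage points higher from compound 3 to compound 4 (within the scatter) and a number 2.1 percentage points lower from compound 1 to compound 4 (within the scatter) as the remaining steps to this compound. Across the four aryl groups now seen on this nitrogen (4-methylphenyl, 4-bromophenyl, 2-methoxyphenyl and 3-(trifluoromethyl)phenyl), the read-out therefore stays flat, and compound 4 goes against that pattern no more than the others do.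

Still open, from the compounds shown here alone, is whether a phenyl group carrying an amine or a carboxylic acid, or a longer alkyl chain in place of the aryl group on this nitrogen, would move the read-out beyond the scatter, and the single tested concentration gives no potency for any of the four compounds. Nothing at hand offers an explanation for the flat result.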